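Swapping one sulfonamide aryl for a chlorothiophene

The compounds below may be only part of what the source reports. "The series", "measured", "known", "first", "only" and "open" are said of these compounds alone.

Measured compounds:
compound 1 `O=S(=O)(Nc1ccc(-c2nc3cc(NS(=O)(=O)c4ccc(Cl)s4)ccc3o2)cc1)c1ccc(Cl)c(C(F)(F)F)c1`: 6100 nM
compound 2 `O=[N+]([O-])c1cc(S(=O)(=O)Nc2ccc3oc(-c4ccc(NS(=O)(=O)c5ccc(Cl)s5)cc4)nc3c2)ccc1Cl`: 1000 nM
compound 3 `O=[N+]([O-])c1cc(S(=O)(=O)Nc2ccc(-c3nc4cc(NS(=O)(=O)c5ccc(Cl)s5)ccc4o3)cc2)ccc1Cl`: 2100 nM

All three share a core carrying two sulfonamides, one of which bears a 5-chlorothiophen-2-yl in each case. In an assay for inhibition of HSP60/HSP10 (Homo sapiens), with a stated time of 60 min (on this read-out lower numbers stand for stronger inhibition and higher numbers for weaker inhibition), compound 3 gives 2100 nM, the second highest of the three numbers; compound 2 sits nearest with 1000 nM, and compound 1 furthest with 6100 nM. Going by the values given here, the one single-point step among the measured compounds is a 2.9-fold lower number from compound 1 to compound 3 (0.46 log units; beyond the scatter), a modest gain.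

Compound 4 `O=S(=O)(Nc1ccc(-c2nc3cc(NS(=O)(=O)c4ccc(Cl)s4)ccc3o2)cc1)c1ccc(Cl)s1` has not yet been measured. It differs from compound 3 by 5-chlorothiophen-2-yl in place of 4-chloro-3-nitrophenyl on a sulfonyl sulfur, so that both sulfonamides of compound 4 carry the same 5-chlorothiophen-2-yl. Among the compounds with values here, no measured step bears directly on this change: the only step known, from compound 1 to compound 3, concerns a substituent on the phenyl that is here removed altogether, and compound 2 differs from compound 3 in the arrangement of the core rather than in this group. The expectation for compound 4 therefore rests on the narrow spread of the three measured values, and it is estimated at 2500 nM, within 800 nM to 8000 nM, a step of a 1.2-fold higher number from compound 3 to compound 4 (0.08 log units; within the scatter) that is expected to stay close to the scatter.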

Compound 4, half-maximal inhibitory concentration: 5900 nM
Estimate against measurement, compound 4: 2.4-fold (0.37 log units) below; the measured number falls inside the stated range.
By their numbers in this assay, from the lowest: compound 2; then compound 3; then compounds 4 and 1 (each within the scatter of the next).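

Replacing 4-chloro-3-nitrophenyl with 5-chlorothiophen-2-yl on a sulfonyl sulfur gives a 2.8-fold higher number from compound 3 to compound 4 (0.45 log units; beyond the scatter), so the number at this position depends on the whole aryl group and not only on the substituent changed between compound 1 and compound 3. Compound 4 carries the same group on both sulfonamides, so it also completes the same exchange at the other sulfonamide of the shared core, giving a 5.9-fold higher number from compound 2 to compound 4 (0.77 log units; beyond the scatter), and the number rises at both places. Exchanging 4-chloro-3-(trifluoromethyl)phenyl for 5-chlorothiophen-2-yl gives a 1.0-fold lower number from compound 1 to compound 4 (0.01 log units; within the scatter), so these two groups cannot be told apart here, and only 4-chloro-3-nitrophenyl stands apart from both on this sulfonyl sulfur.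

The data offer no measurement that explains these steps. The compounds shown leave open whether the nitro group alone accounts for the lower numbers of compound 2 and compound 3, a question that an unsubstituted phenyl, or a phenyl bearing an amine or a carboxylic acid in place of the nitro group, could address at either sulfonamide.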